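A 4-Chlorophenyl Swap at the Assay Limit

The compounds below may be only part of what the source reports. "The series", "measured", "known", "first", "only" and "open" are said of these compounds alone.

In a functional assay on SW-620 cells (Homo sapiens) for antiproliferative activity, read by MTT assay, with a stated time of 24 h (on this read-out lower numbers stand for stronger inhibition and higher numbers for weaker inhibition), compound 1 (`COc1ccc(/C=C/C(=O)c2ccc(OC)c3c2OC(C)(C)C=C3)c(F)c1`) gives a measured value (6570 nM). Compound 2 (`COc1ccc(C(=O)/C=C/c2ccc(-c3ccccc3)cc2)c2c1C=CC(C)(C)O2`) gives only a limit (> 10000 nM). Compound 3 (`COc1ccc(/C=C/C(=O)c2ccc(OC)c3c2OC(C)(C)C=C3)cn1`) also gives only a limit (> 10000 nM), and it therefore has no exact position. Among the compounds with values here, the one measured step (an at least 1.5-fold higher number from compound 1 to compound 3 (0.18 log units; that floor lies within the scatter)) stays within the scatter, and most values sit at one ceiling (the limit of > 10000 nM in this assay, at which 2 of the 3 values shown sit). Compound 4 (`COc1ccc(C(=O)/C=C/c2ccc(Cl)cc2)c2c1C=CC(C)(C)O2`) differs from compound 3 by 4-chlorophenyl in place of 6-methoxypyridin-3-yl on a double-bonded chain carbon bound to a double-bonded chain carbon with 4-chlorophenyl in place of 6-methoxypyridin-3-yl. Within the data shown here, the only number available, from compound 1 (6570 nM), suggests weak inhibition again. For compound 4 a limit remains quite possible. A small move to a lower number is expected (an at least 1.2-fold lower number from compound 3 to compound 4 (0.09 log units; that floor lies within the scatter)). Compound 4 is estimated at 8000 nM (expected range 3000 nM to 20000 nM).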

Compound 4, half-maximal inhibitory concentration: > 10000 nM
Compound 4 was reported as a limit; the forecaster's own chance of this, stated with the estimate: 45%; at least 1.2-fold (0.09 log units) between middle value and limit.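

Compound 4 also ends at a limit of the assay, so 4-chlorophenyl in place of 6-methoxypyridin-3-yl gives no readable change at this place, and the steps from compound 2 and from compound 3 cannot be read. Within the data shown here, the one readable step is an at least 1.5-fold higher number from compound 1 to compound 4 (0.18 log units; that floor lies within the scatter). The ceiling now holds most of the series: the limit of > 10000 nM in this assay, at which 3 of the 4 values shown sit.

Going by these compounds, how far compound 2, compound 3 and compound 4 lie past the limit stays open. So does whether an amine or a carboxylic acid on the aromatic ring at this place would bring a value under it.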